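Replacing the pyridin-2-yl carbamoyl group of compound 1

This account rests on a few compounds, and the source may have more. Where it says the series, first, only, none or still open, it means among the compounds named here.

Compound 1 `O=C(Nc1ccccn1)c1cccc(Nc2ncc(F)c(Nc3ccc(F)cc3)n2)c1`: 13700 nM
Compound 2 `CN1CCC(C(=O)Nc2cccc(Nc3ncc(F)c(Nc4ccc(F)cc4)n3)c2)CC1`: 11900 nM
Compound 3 `O=C(Nc1cccc(Nc2ncc(F)c(Nc3ccc(F)cc3)n2)c1)c1ccccc1`: > 10000 nM, a limit of the assay

In a functional assay on KBVIN cells (Homo sapiens) for antiproliferative activity, read by sulforhodamine B assay, with a stated time of 3 days (on this read-out lower numbers stand for stronger inhibition of growth and higher numbers for weaker inhibition of growth), compound 1 gives 13700 nM. Among the measured compounds shown here, only one other number can be read beside it, that of compound 2, and the two sit close together: a 1.2-fold lower number from compound 1 to compound 2 (0.06 log units; within the scatter). For compound 3 the assay reports only a limit, so the change a step that the limit leaves unreadable from compound 1 to compound 3 cannot be sized, and the same holds for a step that the limit leaves unreadable from compound 2 to compound 3.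

Compound 4 `CN(C)CC(=O)Nc1cccc(Nc2ncc(F)c(Nc3ccc(F)cc3)n2)c1` is not yet measured. It differs from compound 1 in one place: (((dimethylamino)methyl)carbonyl)amino in place of (pyridin-2-yl)carbamoyl on an aromatic carbon. For the measured compounds named here, the step that bears most on this change is the one to compound 2, where an amide carrying a basic amine also replaced the (pyridin-2-yl)carbamoyl group and the number barely moved, a 1.2-fold lower number from compound 1 to compound 2 (0.06 log units; within the scatter). On that ground the step to compound 4 is expected to stay within the scatter, a 1.1-fold lower number from compound 1 to compound 4 (0.06 log units; within the scatter). Compound 4 is therefore estimated at 12000 nM, with a range from 5000 nM to 30000 nM.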

Compound 4, concentration for 50% growth inhibition: 1810 nM
Compound 4: middle estimate off by 6.6-fold (0.82 log units), on the high side; the measured number lies below the stated range.
By their numbers in this assay, from the lowest: compound 4; then compounds 2 and 1 (each within the scatter of the next).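

In this assay, this position on an aromatic carbon, meta to a large group, now shows a real response: (((dimethylamino)methyl)carbonyl)amino in place of (pyridin-2-yl)carbamoyl gives a 7.6-fold lower number from compound 1 to compound 4 (0.88 log units; beyond the scatter). Compound 2 also carries an amine on its amide, yet (dimethylamino)methyl in place of 1-methylpiperidin-4-yl on the carbonyl carbon gives a 6.6-fold lower number from compound 2 to compound 4 (0.82 log units; beyond the scatter), so the presence of an amine alone does not set the number here, and what is attached to that carbonyl carbon matters. Against the phenyl group of compound 3 the step is an at least 5.5-fold lower number from compound 3 to compound 4 (0.74 log units; beyond the scatter), and its size is only a bound, as the value of compound 3 is a limit: the limit of > 10000 nM in this assay, at which 1 of the 4 values shown sits.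

The compounds shown leave open whether the dimethylamino group or the short chain carries this step. A 2-(dimethylamino)ethyl chain, a (diethylamino)methyl group or a plain acetamido group would help to separate the two.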